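Swapping the Aryl Group on a Fused Bicyclic Core

The source may hold more compounds than are shown below. What is called first, only, known or untested is meant among the compounds shown, and "the series" means these compounds.

Measured compounds:
Compound 1 `CS(=O)(=O)c1ccc(Cc2nnc3n2N=C(c2ccccc2)CS3)cc1` gives 46.7% in a functional assay on HT-29 cells (Homo sapiens) for cytotoxicity, read by MTT assay, with a stated time of 48 h, tested at 50 uM; on this read-out lower numbers stand for a weaker effect and higher numbers for a stronger effect at the one concentration tested.
Compound 2 `CS(=O)(=O)c1ccc(Cc2nnc3n2N=C(c2cc(Cl)sc2Cl)CS3)cc1` gives 25.5% in this assay.

Among the compounds with values here, compound 2 is the lower of the two numbers in this assay; the only comparison is with compound 1, which lies beyond the scatter above it. The step to compound 3 `CS(=O)(=O)c1ccc(Cc2nnc3n2N=C(c2ccc(Cl)cc2Cl)CS3)cc1` changes one part: 2,4-dichlorophenyl in place of 2,5-dichlorothiophen-3-yl on a carbon with a double bond to nitrogen.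

Within the data shown here, no measured step matches this exact change. Among the measured compounds shown here, the one step that bears on it replaces the same aryl group at the same place, giving a number 21.2 percentage points lower from compound 1 to compound 2 (beyond the scatter). That shows the aryl group at this carbon can move the read-out by a modest amount, but compound 2 and compound 3 both carry two chlorines on their ring, so the change here is smaller in kind. A step back toward compound 1 is expected, of moderate size and with wide uncertainty, a number 9.5 percentage points higher from compound 2 to compound 3 (within the scatter). Compound 3 is therefore estimated at 35%, with a range from 18% to 52%.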

Compound 3, a percentage reported as activity, at one concentration (the size of the read-out at that concentration, not a potency): 27.3%
The estimate for compound 3 lay 7.7 percentage points above the measured number, within the range that was stated.
By their numbers in this assay, from the lowest: compounds 2 and 3 (each within the scatter of the next); then compound 1.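

In this assay, exchanging the five-membered sulfur ring for a six-membered carbon ring, each carrying two chlorines, leaves the read-out within the scatter (a number 1.8 percentage points higher from compound 2 to compound 3 (within the scatter)). The comparison with the plain phenyl group of compound 1 is beyond the scatter (a number 19.4 percentage points lower from compound 1 to compound 3 (beyond the scatter)), so both dichlorinated aryl groups shown at this carbon give a lower number than phenyl, and neither compound goes against this. Nothing measured here explains that difference, as no supporting evidence accompanies these numbers.

The compounds shown leave open whether a single chlorine on the phenyl ring would give a number like that of compound 1 or like that of compound 3. Also open, on these data alone, is how a phenyl ring carrying a methoxy group or an amine would read at this carbon.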